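The source may report more compounds than this note shows. Statements on the series, on what has been measured and on what is new or still open speak of the compounds shown alone.

Compound 1 `COc1cc(/C=N/Nc2nc3ccccc3s2)cc(OC)c1O` gives 55% in a functional assay on cells (Mus musculus) for cytotoxicity, read by MTT assay, with a stated time of 24 h, tested at 10 uM (on this read-out higher numbers stand for a stronger effect at the one concentration tested and lower numbers for a weaker effect), and stands as the lower of the two numbers measured in the series. For the measured compounds named here, its only measured neighbour is compound 2 `COc1cc(/C=N/N(C)c2nc3ccccc3s2)cc(OC)c1O`, which gives 110% in this assay; the step of a number 55 percentage points higher from compound 1 to compound 2 (beyond the scatter) is the only measured step and is large. Compound 3 `COc1cc(/C=N/Nc2nc3ccccc3s2)cc(OC)c1OC` differs from compound 1 by methyl in place of hydrogen on an oxygen on an aromatic ring. Going by the values given here, no measured step addresses a change on the oxygen; the step from compound 1 to compound 2 concerns a methyl on a nitrogen on an aromatic ring and does not bear on it directly. Among the compounds with values here, the single precedent of a methyl added moved the read-out strongly upward, but without a step at the oxygen the direction for compound 3 stays open. For compound 3 a step of a number 10 percentage points higher from compound 1 to compound 3 (within the scatter) is expected, a modest rise with a wide range. The estimate for compound 3 in this assay is 65%, between 35% and 100%.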

Compound 3, a percentage reported as activity, at one concentration (the size of the read-out at that concentration, not a potency): 57%
The estimate for compound 3 lay 8 percentage points above the measured number; the measured number falls inside the stated range.
By their numbers in this assay, from the lowest: compounds 1 and 3 (each within the scatter of the next); then compound 2.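

Going from hydroxy to methoxy on the aromatic ring gives a number 2 percentage points higher from compound 1 to compound 3 (within the scatter) in this assay and so, on this read-out, the free hydrogen on this oxygen makes no difference that can be told from the scatter. The same methyl placed on the nitrogen on an aromatic ring gives a number 55 percentage points higher from compound 1 to compound 2 (beyond the scatter) and, across these two steps, the outcome of adding a methyl depends on the atom that carries it. Nothing available explains this contrast.

As far as these compounds go, whether ethyl or a longer chain on this oxygen would also stay within the scatter of compound 1 remains open, as does the outcome of placing an amine or a carboxylic acid on the ring in place of hydroxy. Also open, from the compounds shown here alone, is whether methyl on both the oxygen and the nitrogen would match the read-out of compound 2.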